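This account rests on a few compounds, and the source may have more. Where it says the series, first, only, none or still open, it means among the compounds named here.

Measured so far in a physicochemical assay for solubility, at pH 7; a higher number here means a more soluble compound, a lower number a less soluble compound:
- compound 1 `CC(C)(C)C(=O)N1Cc2c(NC(=O)c3cccnc3)n[nH]c2C1(C)C` gives 207000 nM
- compound 2 `CC(C)(C)C(=O)N1Cc2c(NC(=O)c3ccc(F)cc3)n[nH]c2C1(C)C` gives 235000 nM

Among the measured compounds shown here, compound 2 stands level with compound 1, and a 1.1-fold higher number from compound 1 to compound 2 (0.06 log units; within the scatter) is the only measured step. Compound 3 `CCN1CCC(C(=O)N2Cc3c(NC(=O)c4ccc(F)cc4)n[nH]c3C2(C)C)CC1` has 1-ethylpiperidin-4-yl in place of tert-butyl on a carbonyl carbon, counted as 1-ethylpiperidin-4-yl in place of tert-butyl on a carbonyl carbon and with nothing else altered. The measured step swapped a different group, 4-fluorophenyl in place of pyridin-3-yl, so it offers no direct guide to this change. No step beyond the scatter is therefore expected, though with wide uncertainty. The expected step is a 1.0-fold higher number from compound 2 to compound 3 (0.01 log units; within the scatter) in this rough estimate. Compound 3 is estimated at 240000 nM with an expected range from 120000 nM to 480000 nM as a cautious guide.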

Compound 3, solubility: > 225000 nM
Compound 3 gave a limit, no number (the forecaster's own chance of this, stated with the estimate: 15%); the middle value lies beyond the limit too.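

In this assay compound 3 gives > 225000 nM, which is a limit and not a number. The step from compound 2 to compound 3 therefore cannot be read. The compounds shown leave open whether 1-ethylpiperidin-4-yl in place of tert-butyl shifts the number at all.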